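Swapping 3-chlorophenyl for naphthalen-2-yl on compound 1

The source may hold more compounds than are shown below. What is called first, only, known or untested is meant among the compounds shown, and "the series" means these compounds.

Of the compounds shown here, three have numbers so far. In a functional assay on THP-1 cells (Homo sapiens) for inhibition (on this read-out higher numbers stand for weaker inhibition and lower numbers for stronger inhibition), compound 1 (`O=C(CN1CC=CC[C@H](NC(=O)c2cccc(Cl)c2)C1=O)N[C@H]1CC(=O)OC1O`) gives 383 nM, compound 2 (`O=C[C@H](CC(=O)O)NC(=O)[C@@H]1COC[C@@H]2C/C=C\C[C@H](NC(=O)c3nccc4ccccc34)C(=O)N21`) gives 182 nM and compound 3 (`O=C(CN1CC(CO)=CC[C@H](NC(=O)c2ccc3ccccc3c2)C1=O)N[C@H]1CC(=O)OC1O`) gives 543 nM. Compound 1 thus lies within the scatter of compound 3, while compound 2 shows a lower number, beyond the scatter, and so stronger inhibition.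

The next compound is compound 4 (`O=C(CN1CC=CC[C@H](NC(=O)c2ccc3ccccc3c2)C1=O)N[C@H]1CC(=O)OC1O`), which puts naphthalen-2-yl in place of 3-chlorophenyl on a carbonyl carbon. Among the measured compounds shown here, no measured pair isolates this change. The nearest guide is compound 3, which also carries naphthalen-2-yl but has a different core, and which gives 543 nM, within the scatter of compound 1. On that basis, no step beyond the scatter is expected in this assay. The estimated change is small, a 1.1-fold higher number from compound 1 to compound 4 (0.04 log units; within the scatter). For compound 4 the expected value is 420 nM, with an estimated range from 180 nM to 950 nM.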

Compound 4, half-maximal inhibitory concentration: 100 nM
For compound 4 the middle estimate is 4.2-fold (0.62 log units) above the measured one; measured number below the stated range.
By their numbers in this assay, from the lowest: compounds 4 and 2 (each within the scatter of the next); then compounds 1 and 3 (each within the scatter of the next).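

In this assay, the exchange of 3-chlorophenyl for naphthalen-2-yl on a carbonyl carbon, with the rest of the structure unchanged, gives a 3.8-fold lower number from compound 1 to compound 4 (0.58 log units; beyond the scatter), so this position responds to the change of group. With naphthalen-2-yl held fixed, the double-bonded ring carbon also proves to matter, as hydrogen in place of hydroxymethyl gives a 5.4-fold lower number from compound 3 to compound 4 (0.73 log units; beyond the scatter). No measurement is available that explains either step.

The compounds shown leave open whether hydroxymethyl on the double-bonded ring carbon would produce a similar step with 3-chlorophenyl on the carbonyl carbon. They also leave open how an amine or a carboxylic acid at that ring carbon would compare with hydrogen and hydroxymethyl.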